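The compounds below may be only part of what the source reports. "The series", "measured", "known", "first", "only" and "open" are said of these compounds alone.

Measured compounds:
Compound 1 `Cc1ccc(-c2nn(-c3ccc(S(N)(=O)=O)cc3)cc2C=O)cc1` — 58.4%
Compound 2 `Cc1ccc(-c2nn(-c3ccc(S(N)(=O)=O)cc3)cc2/C=N\c2ccc(Cl)cc2)cc1` — 69.1%

Both numbers come from a functional assay on the whole organism (strain Wistar albino) for inhibition, with Rattus norvegicus as the target, read by paw edema, with stated times of 1 h and 2 h, at a dose of 0.32 mmol/kg by the intraperitoneal route; a higher number here means more inhibition at the dose given (going by the name of the read-out), a lower number less inhibition. Within the data shown here, compound 2 stands highest of the two, and the one measured step, a number 10.7 percentage points higher from compound 1 to compound 2 (beyond the scatter), is the only guide available. Compound 3 `COc1ccc(-c2nn(-c3ccc(S(N)(=O)=O)cc3)cc2/C=N\c2ccc(Cl)cc2)cc1` differs from compound 2 by methoxy in place of methyl on an aromatic carbon. Among the measured compounds shown here, that step concerns a different part of the molecule than a number 10.7 percentage points higher from compound 1 to compound 2 (beyond the scatter), so no measured step bears directly on the change; on the six-membered aromatic ring of carbon only, the swap is small. The expected step of a number 1.1 percentage points lower from compound 2 to compound 3 (within the scatter) is none beyond the scatter. Compound 3 is therefore estimated at 68%, between 55% and 80%.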

Compound 3, a percentage reported as inhibition, in the whole organism at one dose (the size of the read-out at that dose, not a potency): 63%
Compound 3: the middle estimate sits 5 percentage points above what was measured; measured number inside the range.
By their numbers in this assay, from the lowest: compounds 1, 3 and 2 (each within the scatter of the next, the first and the last beyond it).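

At the aromatic carbon para to a large group, this assay now gives its first reading of a change on this ring: methoxy in place of methyl gives a number 6.1 percentage points lower from compound 2 to compound 3 (within the scatter). This swap cannot be told apart from the spread of repeated measurements, so either group fits this position at this dose with no clear loss of inhibition.

Going by these compounds, whether an amine, a carboxylic acid or a longer chain at the same place would move the number beyond the scatter stays open. No measurement available here speaks to why the methyl and methoxy compounds read alike.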